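Formyl in place of (propylamino)methyl: three limits, one estimate

A few compounds are considered here, and "the series" means these few. Any claim that something is new, unique, unknown or untested is made for them only; others in the source may bear on it.

Measured compounds:
compound 1 `CCCNCc1ccccc1OCCCCCC(=O)OCC` — > 26000 nM
compound 2 `CCCNCc1ccc(OCCCCCC(=O)OCC)cc1` — > 26000 nM
compound 3 `CCOC(=O)CCCCCOc1ccccc1C=O` — > 26000 nM

Compound 1 and compound 2 are built from the same atoms joined differently; the difference between the two cores is not broken down here. In an ADME assay on HEK293 cells (Homo sapiens) for cytotoxicity, read by CellTiter-Glo and resazurin assay, with a stated time of 72 h (on this read-out lower numbers stand for an effect already at smaller amounts and higher numbers for an effect only at larger amounts of compound), compound 1 gives > 26000 nM, which is a limit of the assay and not a number. Compound 2 gives > 26000 nM in this assay, again a limit. Compound 3 arises from compound 1 by formyl in place of (propylamino)methyl on an aromatic carbon, and in this assay compound 3 gives > 26000 nM, once more a limit. The step that the two limits leave unreadable from compound 1 to compound 3 cannot be read because of the limit of > 26000 nM in this assay, at which 3 of the 3 values shown sit, since every value shown sits at that limit.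

Compound 4 `CCOC(=O)CCCCCOc1ccc(C=O)cc1` has not yet been measured. It differs from compound 2 by formyl in place of (propylamino)methyl on an aromatic carbon. For the measured compounds named here, this is the same kind of change as the one from compound 1 to compound 3, not the same: there the place was ortho to a large group, here it is para to a large group.

For this assay the step from compound 2 to compound 4 is expected to be a step that the limit leaves unreadable from compound 2 to compound 4, which rests on the fact that compound 1, compound 2 and compound 3 all sit at the limit described by the limit of > 26000 nM in this assay, at which 3 of the 3 values shown sit, so no change large enough to leave that limit has been seen. Compound 4 is therefore expected to give about 50000 nM, most likely within 20000 nM to 200000 nM, and quite possibly again only as a limit.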

Compound 4, half-maximal effective concentration: > 26000 nM
Compound 4: no number, only a limit (the forecaster's own chance of this, stated with the estimate: 80%); the middle value does not contradict the limit.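

In this assay compound 4 gives > 26000 nM which is a limit of the assay and not a number. For the compounds shown here, no new step can therefore be read between compound 2 and compound 4, and the size of that change stays unknown: the limit of > 26000 nM in this assay, at which 4 of the 4 values shown sit. The compounds shown leave open whether formyl in place of (propylamino)methyl changes the result in this assay at all, and by how much, on either core.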